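This account rests on a few compounds, and the source may have more. Where it says the series, first, only, none or still open, it means among the compounds named here.

For the measured compounds named here, compound 1 `CCCCCCOc1ccc2c(Cl)ccnc2c1` gives 2080 nM in a functional assay on NCI-H1650 cells (Homo sapiens) for cytotoxicity, read by MTT assay, with a stated time of 48 h (a higher number here means a weaker inhibitor, a lower number a stronger inhibitor), the highest of the two numbers so far; compound 2 `CCCCCCOc1ccc2c(NCCN(C)C)ccnc2c1` gives 930 nM. Going by the values given here, the one measured step, a 2.2-fold lower number from compound 1 to compound 2 (0.35 log units; beyond the scatter), concerns a substituent on an aromatic carbon rather than the chain. Compound 3 `Clc1ccnc2cc(OCCc3ccccc3)ccc12` differs from compound 1 by phenyl in place of butyl on a saturated chain carbon, two bonds along the chain from an oxygen on an aromatic ring. Among the compounds with values here, no measured step touches the chain, so this change has no direct precedent in this assay, and no step beyond the scatter is expected. Compound 3 is estimated at 1800 nM, range 700 nM to 4500 nM. The expected step is a 1.2-fold lower number from compound 1 to compound 3 (0.06 log units; within the scatter).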

Compound 3, half-maximal inhibitory concentration: 2300 nM
Estimate against measurement, compound 3: 1.3-fold (0.11 log units) below; low and high end bracket the measured number.
By their numbers in this assay, from the lowest: compound 2; then compounds 1 and 3 (each within the scatter of the next).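

In this assay, for the compounds shown here, the first measured change on the chain gives a 1.1-fold higher number from compound 1 to compound 3 (0.04 log units; within the scatter), within the scatter. At this saturated chain carbon, two bonds along the chain from an oxygen on an aromatic ring, phenyl and butyl therefore cannot be told apart. Going by these compounds alone, the only step beyond the scatter so far remains the one on the aromatic carbon. Open, from the compounds shown here alone, is whether an amine or a carboxylic acid on the chain would separate from these values, and whether (2-(dimethylamino)ethyl)amino in place of chloro would act alike on compound 3. No supporting evidence on the reason for this result is at hand.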